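The source may report more compounds than this note shows. Statements on the series, on what has been measured and on what is new or still open speak of the compounds shown alone.

Three compounds share one core and differ only in the group attached to one aromatic carbon. Compound 1 `Brc1cn2ccnc2c(-c2ccc3ncn(C4CCCCC4)c3c2)n1` carries a bromo there, compound 2 `c1ccc(-c2cn3ccnc3c(-c3ccc4ncn(C5CCCCC5)c4c3)n2)cc1` a phenyl, and compound 3 `c1cn2cc(-c3ccsc3)nc(-c3ccc4ncn(C5CCCCC5)c4c3)c2n1` a thiophen-3-yl. In a functional assay on MDA-MB-231 cells (Homo sapiens) for inhibition, read by sulforhodamine B assay, with a stated time of 48 h, tested at 10 uM (a higher number here means more inhibition at the concentration tested (going by the name of the read-out), a lower number less inhibition), compound 1 gives 24.2%, compound 2 gives 41.5%, and compound 3 gives 1.35%. Compound 2 stands highest of the three: the step of a number 17.3 percentage points higher from compound 1 to compound 2 (beyond the scatter) is beyond the scatter, and the step of a number 40.2 percentage points lower from compound 2 to compound 3 (beyond the scatter) is larger still, while a number 22.9 percentage points lower from compound 1 to compound 3 (beyond the scatter) also lies beyond the scatter.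

Compound 4 `CC(=O)c1ccc(-c2cn3ccnc3c(-c3ccc4ncn(C5CCCCC5)c4c3)n2)cc1` is compound 2 with one more group: acetyl in place of hydrogen on an aromatic carbon. Among the compounds with values here, no measured step swaps a hydrogen for an acetyl on that phenyl; the measured steps replace the whole group on the core, and they show that this region of the molecule moves the number by modest to large amounts. Because compound 2 already gives 41.5% and the phenyl is kept, compound 4 is expected to stay near it, with the step of a number 0.5 percentage points higher from compound 2 to compound 4 (within the scatter) expected to fall within the scatter, though the uncertainty is wide. The estimate for compound 4 in this assay is 42%, between 20% and 65%.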

Compound 4, a percentage reported as inhibition, at one concentration (the size of the read-out at that concentration, not a potency): 7.65%
Estimate against measurement, compound 4: 34.4 percentage points above, outside the stated range (below it).
By their numbers in this assay, from the lowest: compounds 3 and 4 (each within the scatter of the next); then compound 1; then compound 2.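

Until now, only whole groups on the core had been exchanged, but here the phenyl stays and adding one acetyl to it, para to a large group, gives a number 33.9 percentage points lower from compound 2 to compound 4 (beyond the scatter) in this assay, so a change on the outer part of this group can matter as much as replacing the group. The result also separates the two phenyl-bearing compounds when each is set against the bromo compound: compound 2 stands above it, whereas the 4-acetylphenyl group gives a number 16.6 percentage points lower from compound 1 to compound 4 (beyond the scatter) and so reverses that order. Compound 4 also lands close to the thiophen-3-yl compound, with a number 6.3 percentage points higher from compound 3 to compound 4 (within the scatter), so the two cannot be told apart here, and nothing available explains why the acetyl has this effect.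

The compounds shown leave open whether this loss is particular to acetyl or would also follow from another group at the same place on the phenyl, such as a methyl, an amine or a carboxylic acid. They also leave open whether an acetyl elsewhere on that ring would give a similar number.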